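The source may hold more compounds than are shown below. What is called first, only, known or untested is meant among the compounds shown, and "the series" means these compounds.

Compound 1 `C=C(c1ccc(OC)cc1)c1cc(OC)c(OC)c(OC)c1-c1ccc(F)c(F)c1`: 7500 nM
Compound 2 `C=C(c1ccc(OC)cc1)c1cc(OC)c(OC)c(OC)c1-c1ccc(C(C)(C)C)cc1`: 24000 nM
Compound 3 `C=C(c1ccc(OC)cc1)c1cc(OC)c(OC)c(OC)c1-c1ccc2ccccc2c1`: 6000 nM

All three values come from a functional assay on SK-N-SH cells (Homo sapiens) for cytotoxicity, read by MTT assay, with a stated time of 48 h; a higher number here means a weaker inhibitor, a lower number a stronger inhibitor. Compound 3 shares the low end of these numbers with one other compound: the measurements show a 1.3-fold lower number from compound 1 to compound 3 (0.10 log units; within the scatter). The clear gap lies elsewhere, at a 4.0-fold lower number from compound 2 to compound 3 (0.60 log units; beyond the scatter).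

The unmeasured compound 4 `C=C(c1ccc(OC)cc1)c1cc(OC)c(OC)c(OC)c1-c1ccc(Cl)cc1` keeps the shared core and carries 4-chlorophenyl in place of naphthalen-2-yl on an aromatic carbon.

The useful guides are the steps that changed this same group. Swapping 3,4-difluorophenyl for 4-(tert-butyl)phenyl gave a 3.2-fold higher number from compound 1 to compound 2 (0.51 log units; beyond the scatter), the only kind of swap here that moved the number beyond the scatter. Swapping 3,4-difluorophenyl for naphthalen-2-yl gave only a 1.3-fold lower number from compound 1 to compound 3 (0.10 log units; within the scatter). Among the measured compounds shown here, no measured compound carries 4-chlorophenyl itself. The nearest match is compound 1 at 7500 nM, whose single phenyl ring also bears halogen atoms. On that basis, no step beyond the scatter is expected in this assay, with at most a slight drift towards a higher number. The expected change is a 1.3-fold higher number from compound 3 to compound 4 (0.12 log units; within the scatter). For compound 4 the estimated value is 8000 nM, with an expected range from 3500 nM to 18000 nM.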

Compound 4, half-maximal inhibitory concentration: 15000 nM
Compound 4: middle estimate off by 1.9-fold (0.27 log units), on the low side, and the stated range covers the measured number.
By their numbers in this assay, from the lowest: compounds 3, 1, 4 and 2 (each within the scatter of the next, the first and the last beyond it).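

In this assay, 4-chlorophenyl does not behave like naphthalen-2-yl on this aromatic carbon: the swap gives a 2.5-fold higher number from compound 3 to compound 4 (0.40 log units; beyond the scatter) and so separates naphthalen-2-yl from a second group, not only from 4-(tert-butyl)phenyl. Yet 4-chlorophenyl cannot be told apart from either of the other two groups, with a 1.6-fold lower number from compound 2 to compound 4 (0.20 log units; within the scatter) for one swap and a 2.0-fold higher number from compound 1 to compound 4 (0.30 log units; within the scatter) for the other, even though compound 1 and compound 2 differ beyond the scatter, so compound 4 fits between no clear pair and these groups do not fall into tidy separate levels. Nothing shown explains why the two-ring naphthalen-2-yl group stands apart from 4-chlorophenyl here.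

Going by these compounds, all four compounds keep the shared core and carry only carbon-ring aromatic groups with halogen or alkyl decoration at this position, so it stays open how a phenyl ring bearing an amine or a carboxylic acid would read out. On these data alone, it also stays open whether a plain phenyl ring with no added group would sit with naphthalen-2-yl or with 4-chlorophenyl.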